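A Single Fluorine on a Weakly Growth-Inhibiting Core

The compounds below may be only part of what the source reports. "The series", "measured", "known", "first", "only" and "open" are said of these compounds alone.

Compound 2 `COC(=O)[C@@]1(C)CC[C@@H]2C3=C1CC[C@@H](C)[C@]3(C)C[C@@H]1c3ccccc3N[C@H]21` and compound 1 `COC(=O)[C@@]1(C)CCC=C2[C@@H]1CC[C@@H](C)[C@]2(C)Cc1c(C)[nH]c2ccc(Cl)cc12` belong to the same series and share a common core. In a functional assay on HeLa cells (Homo sapiens) for inhibition, read by sulforhodamine B assay, with a stated time of 48 h (a higher number here means a weaker inhibitor of growth, a lower number a stronger inhibitor of growth), compound 1 gives 12000 nM, and in this assay compound 2 gives 19000 nM. Compound 2 thus holds the higher of the two numbers shown, with compound 1 as its only neighbour, but the two values lie within the scatter of each other, so neither compound can be ranked above the other. Among the measured compounds shown here, compounds 1 and 2 differ from each other in more than one place, so no single step links them.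

Compound 3 `COC(=O)[C@@]1(C)CC[C@@H]2C3=C1CC[C@@H](C)[C@]3(C)C[C@@H]1c3cc(F)ccc3N[C@H]21` is compound 2 with one change: fluoro in place of hydrogen on an aromatic carbon. For the measured compounds named here, no single-point step among the measured compounds is available to calibrate such a change. Given that the change adds only one fluorine with no donor, no acceptor and no charge, the step of a 1.3-fold lower number from compound 2 to compound 3 (0.10 log units; within the scatter) is expected to be small, with no shift beyond the scatter. Compound 3 is therefore estimated at 15000 nM in this assay, within a range of 6000 nM to 40000 nM.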

Compound 3, concentration for 50% growth inhibition: 20000 nM
Estimate against measurement, compound 3: 1.3-fold (0.12 log units) below; the range from low to high includes it.
By their numbers in this assay, from the lowest: compounds 1, 2 and 3 (each within the scatter of the next).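

In this assay, among the compounds shown here, the replacement of hydrogen by fluoro on this aromatic carbon supplies the first step that can be read at a single place, a 1.1-fold higher number from compound 2 to compound 3 (0.02 log units; within the scatter). Compounds 1 and 2 differ in more than one place, so they could say nothing about any one position, whereas this pair isolates a single carbon, meta to a fused ring and para to a fused ring. At that carbon, the added fluorine leaves compound 3 within the scatter of compound 2, so this one change gives no detectable difference in this read-out.

Going by these compounds, it remains open whether an amine, a carboxylic acid or a methoxy group on the same carbon would give a step beyond the scatter. For the compounds shown here, also open is whether fluoro on the other aromatic carbons of this ring would read the same way as it does here, since a single step describes only one position and one group. No measurement shown here offers an explanation for the size of this step.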